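The compounds below may be only part of what the source reports. "The series", "measured", "known", "first", "only" and "open" are said of these compounds alone.

Going by the values given here, this piece follows a single change, from compound 2 `COc1ccc([C@H]2Oc3cc(O)cc(O)c3C(=O)[C@@H]2O)cc1` to compound 3 `COc1ccc([C@@H]2Oc3cc(O)cc(O)c3C(=O)[C@H]2O)cc1`, with compound 1 `COc1cccc([C@@H]2Oc3cc(O)cc(O)c3C(=O)[C@H]2O)c1` as the only other compound measured. All readings come from a physicochemical assay, read by spectrophotometry, with a stated time of 30 min; a higher number here means that more compound is needed for the effect, a lower number that less compound is needed.

In this assay compound 1 gives only a limit, > 100000 nM, not a number. In this assay compound 2 likewise gives only a limit, > 100000 nM. The shared position of these two readings is the limit of > 100000 nM in this assay, at which 2 of the 2 values shown sit. So compound 2 stands at the edge of what this assay can report, without a number of its own, and compound 1 stands in the same spot.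

Compound 3 differs from compound 2 only in how its stereocentres are drawn: the two compounds have the same atoms and bonds and differ only in configuration as drawn: 2 of 2 stereo elements differ (all stereocentres are inverted: mirror images); a stereocentre at a saturated ring carbon is drawn R in compound 2 and S in compound 3; a stereocentre at a saturated ring carbon is drawn R in compound 2 and S in compound 3. Among the compounds with values here, no pair of measured compounds differs in one place, so no measured step is available to set a scale. Since compound 2 gives only a limit in this assay, there is no number to move away from, and no step beyond the scatter is expected in either direction. Compound 3 is expected to give 150000 nM in this assay, within a range from 100000 nM to 300000 nM. The expected step that this estimate means, a step that the limit leaves unreadable from compound 2 to compound 3, lies within the scatter.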

Compound 3, half-maximal effective concentration: > 100000 nM
Compound 3 gave a limit, no number; the forecaster's own chance of this, stated with the estimate: 90%; the middle value is on the limit's open side.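

In this assay compound 3 gives > 100000 nM, which is a limit and not a number. Compound 2 also gives only a limit, so no step can be read between these two mirror images. The compounds shown leave open whether the two mirror images truly differ, and what change to the shared core would give a readable number.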